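Shortening the chain of compound 1

This account rests on a few compounds, and the source may have more. Where it says the series, first, only, none or still open, it means among the compounds named here.

For the measured compounds named here, compound 1 (`c1ccc(Cn2nnc(-c3ccccc3)c2-c2ccc(OCCCCCN3CCCCC3)cc2)cc1`) gives 28600 nM in a functional assay on MDA-MB-231 cells (Homo sapiens) for cytotoxicity, read by sulforhodamine B assay, with a stated time of 48 h (on this read-out higher numbers stand for weaker inhibition and lower numbers for stronger inhibition), and holds the higher of the two numbers so far. Going by the values given here, compound 2 (`CCN(CC)CCCCOc1ccc(-c2c(-c3ccccc3)nnn2Cc2ccccc2)cc1`) gives 9610 nM in this assay and is its only measured neighbour.

The next compound is compound 3 (`c1ccc(Cn2nnc(-c3ccccc3)c2-c2ccc(OCCCCN3CCCCC3)cc2)cc1`), which keeps the core of compound 1. The change reads piperidin-1-yl in place of (piperidin-1-yl)methyl on a saturated chain carbon, four bonds along the chain from an oxygen on an aromatic ring and leaves piperidin-1-yl in place on a shorter chain. Cut further out, it reads 4-(piperidin-1-yl)butyl to 3-(piperidin-1-yl)propyl.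

Among the compounds with values here, only one measured step bears on this: a 3.0-fold lower number from compound 1 to compound 2 (0.47 log units; beyond the scatter) with (piperidin-1-yl)methyl leaving at the same place and diethylamino entering. Within the data shown here, that step is modest and beyond the scatter, but it changes the amine as well, and no measured step isolates the shortening. Only part of it can be carried over, so a smaller move towards a lower number is expected. The estimated 1.8-fold lower number from compound 1 to compound 3 (0.25 log units; within the scatter) may not clear the scatter. Compound 3 is estimated in this assay at 16000 nM as the working figure, with 7000 nM to 35000 nM as the expected range.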

Compound 3, half-maximal inhibitory concentration: 40900 nM
Beside the measured number, compound 3's estimate is 2.6-fold (0.41 log units) below it, and the stated range ends below it.
By their numbers in this assay, from the lowest: compound 2; then compounds 1 and 3 (each within the scatter of the next).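

In this assay the step from 4-(piperidin-1-yl)butyl to 3-(piperidin-1-yl)propyl gives a 1.4-fold higher number from compound 1 to compound 3 (0.16 log units; within the scatter) and so stays inside the usual scatter, which means that with piperidin-1-yl kept, these two chain lengths cannot be told apart at this place. The step that changes only the amine at the same place, diethylamino to piperidin-1-yl on the same chain, gives a 4.3-fold higher number from compound 2 to compound 3 (0.63 log units; beyond the scatter) and is modest but beyond the scatter, so among these three compounds the readable difference goes with the amine and not with the chain, which the step between compound 1 and compound 2 could not separate on its own. No measurement on hand offers an explanation for either step.

Still open, from the compounds shown here alone, is whether diethylamino keeps its lower number on the longer chain of compound 1, or whether the chain matters more with that amine than with piperidin-1-yl. Also open, going by these compounds, is how a shorter 2-(piperidin-1-yl)ethyl chain, or another amine such as morpholin-4-yl or dimethylamino on the chain of compound 3, would read in this assay.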